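Naphthyl ether extends a triazole sulfonamide series at the limit

The source may report more compounds than this note shows. Statements on the series, on what has been measured and on what is new or still open speak of the compounds shown alone.

Compound 1 `Cc1ccccc1OCc1cn(-c2ccc(S(=O)(=O)N3CCc4ccccc4C3)cc2)nn1`: in a functional assay on HuCC-A1 cells (Homo sapiens) for cytotoxicity, read by MTT assay, with a stated time of 48 h (a higher number here means a weaker inhibitor, a lower number a stronger inhibitor), compound 1 gives > 50 ug/mL, which is a limit of the assay and not a number.
Compound 2 `O=Cc1ccc(OCc2cn(-c3ccc(S(=O)(=O)N4CCc5ccccc5C4)cc3)nn2)cc1`: in this assay compound 2 gives > 50 ug/mL, again a limit.
Compound 3 `O=S(=O)(c1ccc(-n2cc(COc3ccccc3)nn2)cc1)N1CCc2ccccc2C1`: in this assay compound 3 gives > 50 ug/mL, also a limit.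

For the measured compounds named here, compound 3 therefore stands where every measured compound stands, at the limit of > 50 ug/mL in this assay, at which 3 of the 3 values shown sit; no compound is resolved as stronger or weaker than another. The change to compound 4 `O=S(=O)(c1ccc(-n2cc(COc3ccc4ccccc4c3)nn2)cc1)N1CCc2ccccc2C1` is naphthalen-2-yl in place of phenyl on an oxygen on a saturated carbon. Going by the values given here, none of the measured steps touches this change. The steps a step that the two limits leave unreadable from compound 1 to compound 2, a step that the two limits leave unreadable from compound 1 to compound 3 and a step that the two limits leave unreadable from compound 2 to compound 3 are each unreadable in size, both ends sitting at the limit. Among the compounds with values here, no direction or size of step can be drawn from them for compound 4 in this assay; the only guide is that the three measured values all sit at the limit. Compound 4 is accordingly expected to give an estimate of 60 ug/mL, with a range from 20 ug/mL to 200 ug/mL. This estimate corresponds to an expected step that the limit leaves unreadable from compound 3 to compound 4, with a strong chance that only a limit is reported.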

Compound 4, half-maximal inhibitory concentration: > 50 ug/mL
Compound 4: no number, only a limit; the forecaster's own chance of this, stated with the estimate: 70%; the middle value does not contradict the limit.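

In this assay compound 4 gives > 50 ug/mL, which is a limit and not a number. The steps to compound 4 from compound 1, compound 2 and compound 3 therefore cannot be read, as all four compounds sit at the same limit: the limit of > 50 ug/mL in this assay, at which 4 of the 4 values shown sit.

The compounds shown leave open whether any of the groups on the oxygen differs from another in this assay.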